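A Mirror-Image Stereocentre, Measured Before and After

A few compounds are considered here, and "the series" means these few. Any claim that something is new, unique, unknown or untested is made for them only; others in the source may bear on it.

Of the compounds shown here, two have been tested in a functional assay on MDA-MB-231 cells (Homo sapiens) for activation, read by flow cytometry and annexin V staining; on this read-out higher numbers stand for an effect only at larger amounts of compound and lower numbers for an effect already at smaller amounts. Compound 1 `CC(C)CCCC(C)CCCC(C)CCOCC1(C)CCc2cc(OCC(=O)O)c(F)cc2O1` gives 27000 nM in this assay. Compound 2 `Cc1c(C)c2c(c(C)c1OCC(=O)O)CC[C@](C)(COCCC(C)CCCC(C)CCCC(C)C)O2` gives 16000 nM in this assay; the numbers for compound 2 and compound 1 lie within the scatter of each other, so neither can be called the more active of the two.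

Compound 3 `Cc1c(C)c2c(c(C)c1OCC(=O)O)CC[C@@](C)(COCCC(C)CCCC(C)CCCC(C)C)O2` is the partner of compound 2 in which (the two compounds have the same atoms and bonds; at least one stereo element is drawn with a configuration in one of them and without one in the other: 1 of 3 stereo elements differ; a stereocentre at a saturated ring carbon is drawn R in compound 2 and S in compound 3). Among the compounds with values here, no pair of measured compounds shows a step of this kind, so there is no measured guide to its size or direction. A change only in the drawn configuration of one stereocentre is expected to move the number little, so the expected step from compound 2 to compound 3 in this assay is no change at the digits printed from compound 2 to compound 3 (within the scatter), with no clear direction. Compound 3 is therefore estimated to give 16000 nM in this assay, within a range from 6000 nM to 40000 nM.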

Compound 3, half-maximal effective concentration: 18000 nM
Compound 3: middle estimate off by 1.1-fold (0.05 log units), on the low side, within the range that was stated.
By their numbers in this assay, from the lowest: compounds 2, 3 and 1 (each within the scatter of the next).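

Drawing the saturated ring carbon as S instead of R gives a 1.1-fold higher number from compound 2 to compound 3 (0.05 log units; within the scatter) in this assay. Within the data shown here, this is the first measured step at this stereocentre, and it shows that the read-out does not separate the two drawn configurations: neither compound 2 nor compound 3 can be called the more active. One caution applies to how far this comparison can be pressed, since it rests on how the structures are drawn: the fact that one of compounds 2 and 3 is drawn with a defined configuration and the other without, at the place where they differ

The compounds shown leave open whether this stereocentre would stay as silent with a different group at the end of the side on the shared core, for example an amine or a primary amide in place of the carboxylic acid. They also leave open whether a shorter chain in place of the long branched one would let the two configurations be told apart.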